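Permeability notes: from compound 2 to compound 3

The source may report more compounds than this note shows. Statements on the series, on what has been measured and on what is new or still open speak of the compounds shown alone.

Measured in an ADME assay for permeability; a lower number here means that the compound crosses the layer more slowly, a higher number that the compound crosses the layer faster: compound 1 `CNC(=O)c1cc(C(=O)N[C@H]2CC[C@H](O)CC2)n([C@@H](C)c2ccccc2)n1` gives 80 nm/s; compound 2 `CC[C@@H](c1ccccc1)n1nc(C(=O)NC)cc1C(=O)N[C@H]1CC[C@H](O)CC1` gives 70 nm/s.

Compound 2 sits within the scatter of compound 1, so the two numbers are not distinguishable. Compound 3 `CNC(=O)c1cc(C(=O)N[C@H]2CC[C@H](O)CC2)n([C@@H](C)c2cccc(C)c2)n1` is the next step: 1-(3-methylphenyl)ethyl in place of 1-phenylpropyl on an aromatic nitrogen. Within the data shown here, the only measured step that bears on it, a 1.1-fold lower number from compound 1 to compound 2 (0.06 log units; within the scatter), altered the same chain and stayed within the scatter. Among the measured compounds shown here, no measured step touches the methyl on the aromatic ring. The expected step is therefore none beyond the scatter, a 1.1-fold higher number from compound 2 to compound 3 (0.06 log units; within the scatter). Compound 3 is estimated at 80 nm/s, in a range from 45 nm/s to 140 nm/s.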

Compound 3, apparent permeability in the ADME assay: 110 nm/s
Beside the measured number, compound 3's estimate is 1.4-fold (0.14 log units) below it; low and high end bracket the measured number.
By their numbers in the ADME assay, from the lowest: compounds 2, 1 and 3 (each within the scatter of the next).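

In the ADME assay a methyl on an aromatic carbon of the group on the aromatic nitrogen stays within the scatter (a 1.4-fold higher number from compound 1 to compound 3 (0.14 log units; within the scatter)), and so does the full change to 1-(3-methylphenyl)ethyl from 1-phenylpropyl (a 1.6-fold higher number from compound 2 to compound 3 (0.20 log units; within the scatter)). In a physicochemical assay for lipophilicity (a lower number here means a more polar compound, a higher number a more lipophilic compound), compound 3 gives 3.4 and compound 2 gives "not determined" (no result reported), so no step can be read there. No evidence at hand bears on these numbers. Still open, from the compounds shown here alone, is whether an amine on that aromatic ring, or a longer chain in place of the methyl on the saturated carbon, would move the number in the ADME assay beyond the scatter.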